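This account rests on a few compounds, and the source may have more. Where it says the series, first, only, none or still open, it means among the compounds named here.

Measured in a functional assay on BaF3 cells (Mus musculus) for inhibition, read by MTT assay, with a stated time of 3 days; on this read-out higher numbers stand for weaker inhibition of growth and lower numbers for stronger inhibition of growth:
- Compound 1 `COc1ccc(NC(=O)Nc2ccc(Nc3ncnc4c3OCCN4)cc2)cc1`: > 10000 nM (a limit)
- Compound 2 `COc1cccc(NC(=O)Nc2ccc(Nc3ncnc4c3OCCN4)cc2)c1`: > 10000 nM (a limit)
- Compound 3 `Cc1ccc(F)c(NC(=O)Nc2ccc(Nc3ncnc4c3OCCN4)cc2)c1`: > 10000 nM (a limit)

Compound 3 has no number, only a limit, and the series as a whole shows (the limit of > 10000 nM in this assay, at which 3 of the 3 values shown sit). Compound 4 `Cc1cc(C)cc(NC(=O)Nc2ccc(Nc3ncnc4c3OCCN4)cc2)c1` carries 3,5-dimethylphenyl in place of 2-fluoro-5-methylphenyl on an amide-type nitrogen. The measured changes at this same place are a step that the two limits leave unreadable from compound 1 to compound 2, a step that the two limits leave unreadable from compound 1 to compound 3 and a step that the two limits leave unreadable from compound 2 to compound 3, and none of them gives a size. From compound 3 at > 10000 nM no direction can be drawn, so no step beyond the scatter is expected. The expected change is a number no higher from compound 3 to compound 4 (the limit leaves the size open) in this assay as estimated here. The estimate for compound 4 is 10000 nM, with an expected range of 4000 nM to 20000 nM.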

Compound 4, concentration for 50% growth inhibition: > 10000 nM
Compound 4: a limit, no number (the forecaster's own chance of this, stated with the estimate: 85%); the middle value lies on the limit itself.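

In this assay, going by these compounds alone, compound 4 gives > 10000 nM, a limit, so no step among compound 1, compound 2, compound 3 and compound 4 can be read. Whether any group on the amide-type nitrogen would give a measurable number stays open, as the series stands: the limit of > 10000 nM in this assay, at which 4 of the 4 values shown sit.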